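The source may hold more compounds than are shown below. What is called first, only, known or untested is meant among the compounds shown, and "the series" means these compounds.

Measured in an ADME assay on cells (Platelet, Homo sapiens) for inhibition, read by turbidimetry, with a stated time of 2 min; a lower number here means a stronger inhibitor, a higher number a weaker inhibitor:
- compound 1 `Cc1cc(C(=O)N/N=C/c2ccc([N+](=O)[O-])cc2)c2c(C)nn(-c3ccccc3)c2n1`: > 100000 nM (a limit)
- compound 2 `Cc1cc(C(=O)N/N=C/c2ccc(Br)cc2)c2c(C)nn(-c3ccccc3)c2n1`: > 100000 nM (a limit)

Compound 1 stands only at a limit, > 100000 nM, so it offers no number to start from. Compound 3 `Cc1ccc(/C=N/NC(=O)c2cc(C)nc3c2c(C)nn3-c2ccccc2)cc1` differs from it by methyl in place of nitro on an aromatic carbon. For the measured compounds named here, the one measured step at this place is a step that the two limits leave unreadable from compound 1 to compound 2, and the only other evidence is the limit of > 100000 nM in this assay, at which 2 of the 2 values shown sit. In this assay, no readable step and no clear direction are therefore expected, and another limit is the likeliest result. The expected change is a step that the limit leaves unreadable from compound 1 to compound 3. Compound 3 is estimated at 150000 nM, with an expected range of 60000 nM to 400000 nM.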

Compound 3, half-maximal inhibitory concentration: > 100000 nM
Compound 3 gave a limit, no number; the forecaster's own chance of this, stated with the estimate: 80%; the middle value is on the limit's open side.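

No step can be read among compound 1, compound 2 and compound 3, as each gives only a limit and no number: the limit of > 100000 nM in this assay, at which 3 of the 3 values shown sit.

The compounds shown leave open whether any group at this place gives a readable value in this assay.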